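Swapping the ester of compound 1 for its reversed form

The compounds below may be only part of what the source reports. "The series", "measured", "known", "first", "only" and "open" are said of these compounds alone.

Among the measured compounds shown here, compound 1 `CCOC(=O)c1c(C)coc1-c1ccc2c(CC)cccc2c1OC` is the only member of this small set with a measured number: in a functional assay on SK-BR-3 cells (Homo sapiens) for cytotoxicity, read by MTT assay, with a stated time of 72 h (a lower number here means that less compound is needed, a higher number that more compound is needed for the effect), compound 1 gives 2.5 ug/mL. Compound 2 `CCCOC(=O)c1c(C)coc1-c1ccc2c(CC)cccc2c1OC` gives only a limit, > 10 ug/mL. Compound 3 `CCc1cccc2c(OC)c(-c3occ(C)c3C(=O)NC)ccc12` also gives only a limit, > 10 ug/mL. Both of these measured changes sit on the ester group of compound 1: a methyl in place of hydrogen on a saturated chain carbon, two bonds along the chain from an oxygen next to a carbonyl group, gave an at least 4.0-fold higher number from compound 1 to compound 2 (0.60 log units; beyond the scatter), and methylamino in place of ethoxy on a carbonyl carbon gave an at least 4.0-fold higher number from compound 1 to compound 3 (0.60 log units; beyond the scatter). Compound 4 `CCc1cccc2c(OC)c(-c3occ(C)c3COC(C)=O)ccc12` differs from compound 1 by acetoxymethyl in place of ethoxycarbonyl on an aromatic carbon. With an at least 4.0-fold higher number from compound 1 to compound 2 (0.60 log units; beyond the scatter) and an at least 4.0-fold higher number from compound 1 to compound 3 (0.60 log units; beyond the scatter) both pointing toward a higher number, the expected change here is a 3.2-fold higher number from compound 1 to compound 4 (0.51 log units; beyond the scatter). Compound 4 is therefore estimated at 8 ug/mL, with a range from 3 ug/mL to 25 ug/mL.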

Compound 4, concentration for half-maximal effect: > 10 ug/mL
Compound 4: no number, only a limit (the forecaster's own chance of this, stated with the estimate: 45%); at least 1.2-fold (0.09 log units) between middle value and limit.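

Compound 4 gives only a limit, not a number. Even so, acetoxymethyl in place of ethoxycarbonyl gives an at least 4.0-fold higher number from compound 1 to compound 4 (0.60 log units; beyond the scatter), although the two groups hold the same atoms, so at this position how the atoms are joined matters, not only which atoms are present. The steps among compounds 2, 3 and 4 cannot be read, because all three stop at the same value: the limit of > 10 ug/mL in this assay, at which 3 of the 4 values shown sit.

As far as these compounds go, what a carboxylic acid or a hydroxymethyl group would give at this position stays open. So does whether any group here could give a lower number than compound 1.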